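A few compounds are considered here, and "the series" means these few. Any claim that something is new, unique, unknown or untested is made for them only; others in the source may bear on it.

Measured in a functional assay on NCI-H1975 cells (Homo sapiens) for inhibition, read by MTT assay, with a stated time of 72 h; a higher number here means a weaker inhibitor, a lower number a stronger inhibitor:
Compound 1 `FC(F)(F)c1ccc(CSc2nc(Sc3ncccn3)cc(C(F)(F)F)n2)cc1` gives 14000 nM
Compound 2 `FC(F)(F)c1ccc(CSc2nc(Sc3ccccn3)cc(C(F)(F)F)n2)cc1` gives 23900 nM

In this assay compound 2 stands at 23900 nM, within the scatter of compound 1. Compound 3 `FC(F)(F)c1ccc(CSc2nc(Sc3nnnn3-c3ccccc3)cc(C(F)(F)F)n2)cc1`, not yet measured, carries 1-phenyl-1H-tetrazol-5-yl in place of pyridin-2-yl on a sulfur, and the counted difference is 1-phenyl-1H-tetrazol-5-yl in place of pyridin-2-yl on a sulfur. For the measured compounds named here, one measured step bears on this change, at the same sulfur: a 1.7-fold higher number from compound 1 to compound 2 (0.23 log units; within the scatter). That step exchanges one six-membered aromatic ring for another, whereas compound 3 brings in two rings, so it is only a weak guide. The data therefore give no direction, and no change beyond the scatter is expected. The expected change is a 1.3-fold lower number from compound 2 to compound 3 (0.12 log units; within the scatter). For compound 3 the estimated value is 18000 nM, with an expected range from 6000 nM to 50000 nM.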

Compound 3, half-maximal inhibitory concentration: 24300 nM
For compound 3 the middle estimate is 1.4-fold (0.13 log units) below the measured one, and the stated range covers the measured number.
By their numbers in this assay, from the lowest: compounds 1, 2 and 3 (each within the scatter of the next).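

In this assay this sulfur position accepts a far bigger change than the earlier pair could show: that pair only exchanged one six-membered aromatic ring for another, whereas 1-phenyl-1H-tetrazol-5-yl brings in a five-membered aromatic ring with 4 hetero atoms plus a six-membered carbon ring. Against pyridin-2-yl the result is a 1.0-fold higher number from compound 2 to compound 3 (0.01 log units; within the scatter), and against pyrimidin-2-yl it is a 1.7-fold higher number from compound 1 to compound 3 (0.24 log units; within the scatter), so neither the second ring nor the added ring nitrogens moves the number beyond the scatter. No evidence is available on what lies behind this flat result.

On these data alone, all three groups on this sulfur are aromatic rings, so it remains open whether in this assay an amine, a carboxylic acid or a longer alkyl chain there would shift the number. Also open, as far as these compounds go, is whether changes elsewhere on the shared core would do so.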